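A few compounds are considered here, and "the series" means these few. Any claim that something is new, unique, unknown or untested is made for them only; others in the source may bear on it.

Measured compounds:
compound 1 `O=C1NC(=S)S/C1=C\C1=Cc2cc(Br)ccc2OC1` gives 40400 nM
compound 2 `O=C(O)CN1C(=O)/C(=C/C2=Cc3cc(Br)ccc3OC2)SC1=S` gives > 25000 nM, a limit
compound 3 `CC1Oc2ccc(Br)cc2C=C1/C=C1\SC(=S)NC1=O` gives 19900 nM

All three share the core of compound 1. In a functional assay on MCF7 cells (Homo sapiens) for antiproliferative activity, read by MTT assay, with a stated time of 72 h (a higher number here means a weaker inhibitor, a lower number a stronger inhibitor), compound 1 gives 40400 nM. Compound 2 carries a carboxymethyl in place of hydrogen on the amide-type nitrogen in the ring; in this assay compound 2 gives > 25000 nM, which is a limit of the assay and not a number. Compound 3 carries a methyl in place of hydrogen on a saturated ring carbon, and in this assay compound 3 gives 19900 nM. Compound 3 thus stands lowest of the two readable numbers, with compound 1 nearest; the step of a 2.0-fold lower number from compound 1 to compound 3 (0.31 log units; beyond the scatter) lies beyond the scatter. The step that the limit leaves unreadable from compound 1 to compound 2 stays unreadable because the limit of > 25000 nM in this assay, at which 1 of the 3 values shown sits, hides its size.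

Compound 4 `CC1Oc2ccc(Br)cc2C=C1/C=C1\SC(=S)N(CC(=O)O)C1=O` differs from compound 3 in one place: carboxymethyl in place of hydrogen on an amide-type nitrogen in a ring. Going by the values given here, the only step that bears on it is the one from compound 1 to compound 2, the same change on the same nitrogen, whose size cannot be read; the value of compound 2 shows only that it did not fall to a readable number. Compound 4 is therefore expected to move toward a higher number, by an estimated step of a 1.6-fold higher number from compound 3 to compound 4 (0.21 log units; within the scatter) in this assay, and may well again return only a limit. Compound 4 is estimated at 32000 nM, within 12000 nM to 90000 nM.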

Compound 4, half-maximal inhibitory concentration: > 50000 nM
Compound 4 ended at the assay's limit; the forecaster's own chance of this, stated with the estimate: 55%; middle value at least 1.5-fold (0.19 log units) from the limit.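

The carboxymethyl in place of hydrogen on the amide-type nitrogen in a ring now has a readable lower bound: in this assay it gives an at least 2.5-fold higher number from compound 3 to compound 4 (0.40 log units; beyond the scatter). The earlier pair, compound 1 and compound 2, left the size of this change hidden, whereas the pair with the methyl on the saturated ring carbon shows a rise beyond the scatter, so the carboxymethyl gives no readable number in either of the two pairs. Compound 4 stands at a limit of the assay and not at a number, so its step is only a floor, and the step between compound 2 and compound 4, where the methyl could have been compared with the carboxymethyl present, cannot be read: the limit of > 50000 nM in this assay, at which 1 of the 4 values shown sits.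

The compounds shown leave open how far compound 4 truly lies from compound 3, and so whether the methyl on the saturated ring carbon makes any difference once the carboxymethyl is present. They also leave open whether a plain methyl, an ethyl ester of the carboxylic acid or a longer chain ending in a carboxylic acid on the same nitrogen would return a readable number.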